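Dimethylamino in place of the compound 2 side group

The source may report more compounds than this note shows. Statements on the series, on what has been measured and on what is new or still open speak of the compounds shown alone.

In a functional assay on A20 cells (Mus musculus) for inhibition, with stated times of 1 h, 16 h and 24 h (on this read-out lower numbers stand for stronger inhibition and higher numbers for weaker inhibition), compound 1 (`N#CC1(NC(=O)[C@@H]2C[C@@H](S(=O)(=O)c3ccccc3)C[C@H]2C(=O)N2CCNCC2)CC1`) gives 1340 nM. Within the data shown here, compound 2 (`N#CC1(NC(=O)[C@@H]2C[C@@H](S(=O)(=O)c3ccccc3)C[C@H]2C(=O)N2CCC(O)CC2)CC1`) gives 371 nM, the lower of the two numbers so far. Compound 3 (`CN(C)C(=O)[C@@H]1C[C@H](S(=O)(=O)c2ccccc2)C[C@H]1C(=O)NC1(C#N)CC1`) has dimethylamino in place of 4-hydroxypiperidin-1-yl on a carbonyl carbon.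

Among the measured compounds shown here, one measured step bears on this change, at a carbonyl carbon too: a 3.6-fold lower number from compound 1 to compound 2 (0.56 log units; beyond the scatter), modest but beyond the scatter. It shows that the number moves with the group there, yet it involves only ring-bearing groups, so it gives no direct reading for dimethylamino. With compound 2 at 371 nM as the low point of a two-compound series, a modest move to a higher number in this assay is expected, though a step within the scatter remains possible. The expected step is a 1.5-fold higher number from compound 2 to compound 3 (0.17 log units; within the scatter). For compound 3 the estimate is 550 nM, with an expected range of 170 nM to 1700 nM.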

Compound 3, half-maximal inhibitory concentration: 91 nM
The estimate for compound 3 lay 6.0-fold (0.78 log units) above the measured number; measured number outside the range, below it.
By their numbers in this assay, from the lowest: compound 3; then compound 2; then compound 1.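

Within this assay the move to dimethylamino gives a 4.1-fold lower number from compound 2 to compound 3 (0.61 log units; beyond the scatter) and so shows that a ring is not required on this carbonyl carbon for a lower number. Against piperazin-1-yl the same group gives a 15-fold lower number from compound 1 to compound 3 (1.17 log units; beyond the scatter) and this large step places compound 3 lowest of the three, with 3 heavy atoms against 7 for 4-hydroxypiperidin-1-yl and no hydrogen-bond donor. No available evidence accounts for this result.

The compounds shown do not separate loss of the ring from loss of the hydroxyl, a question that piperidin-1-yl or a hydroxyethyl(methyl)amino group would address. Going by these compounds, it also remains open whether the trend continues to methylamino or an unsubstituted amino group, or whether it reverses with longer chains such as diethylamino.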